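This account rests on a few compounds, and the source may have more. Where it says the series, first, only, none or still open, it means among the compounds named here.

Measured so far, in a functional assay on DLD-1 cells (Homo sapiens) for antiproliferative activity, read by CellTiter-Glo, with a stated time of 72 h; on this read-out higher numbers stand for weaker inhibition and lower numbers for stronger inhibition:
- compound 1, `Cc1ccc(-c2cccc(S(=O)(=O)N3CCC(N4CCC(C)CC4)CC3)c2)cc1`, gives 11 nM
- compound 2, `COc1ccccc1-c1ccc(S(=O)(=O)N2CCC(N3CCC(C)CC3)CC2)cc1`, gives 26 nM
- compound 3, `Cc1cc(C)c(S(=O)(=O)c2ccc(N3CCC(C)CC3)cc2)c(C)c1`, gives only a limit of the assay, > 5000 nM

Of the two numbers that are known, compound 2 has the higher one; the nearest is compound 1, whose number is lower by a margin that lies beyond the scatter of repeated measurements. For compound 3 the assay reports a limit rather than a number (the limit of > 5000 nM in this assay, at which 1 of the 3 values shown sits), so it cannot be ranked against the others.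

The next compound, compound 4, `COC(=O)c1ccc(S(=O)(=O)N2CCC(N3CCC(C)CC3)CC2)cc1`, has not yet been measured in this assay. It differs from compound 2 in one place: methoxycarbonyl in place of 2-methoxyphenyl on an aromatic carbon. The 2-methoxyphenyl that leaves is the larger part of the molecule on that side; the methoxycarbonyl that enters is smaller and has no ring.

Among the measured compounds shown here, no measured pair shows this kind of change, so the expectation rests on compound 2 alone. A loss of potency from compound 2 to compound 4 is expected, estimated at a 12-fold higher number from compound 2 to compound 4 (1.06 log units; beyond the scatter), a step beyond the scatter. Compound 4 is therefore expected to give about 300 nM, within a range from 60 nM to 2000 nM.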

Compound 4, half-maximal inhibitory concentration: > 5000 nM
Compound 4: only a limit was reported; the forecaster's own chance of this, stated with the estimate: 10%; middle value at least 16-fold (1.22 log units) away from the limit.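

In this assay, compound 4 gives > 5000 nM, which is a limit of the assay and not a number. Among the compounds shown here, this is the first comparison in which only one place changes: putting methoxycarbonyl in place of 2-methoxyphenyl on this aromatic carbon, para to a large group, gives an at least 190-fold higher number from compound 2 to compound 4 (2.28 log units; beyond the scatter), so the group at this place has a large bearing on the read-out. Compound 4 can be ranked no more exactly than compound 3, since neither has a number: the limit of > 5000 nM in this assay, at which 2 of the 4 values shown sit.

This single pair cannot separate the loss of the aromatic ring from the arrival of the methoxycarbonyl. On these data alone, whether an unsubstituted phenyl, a carboxylic acid, an amine or a simple ethyl chain at this place would restore potency remains open, as does how weak compound 4 really is.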